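The source may report more compounds than this note shows. Statements on the series, on what has been measured and on what is new or still open speak of the compounds shown alone.

Compound 1 `Cc1ccc(C(=O)Nc2cccc(-c3oc4cc(-c5ccc(F)cc5)ccc4c(=O)c3O)c2)cc1` gives 12900 nM in a functional assay on GTL 16 cells for antiproliferative activity against GTL 16 cell line (Homo sapiens), read by CCK-8 assay, with a stated time of 72 h; on this read-out higher numbers stand for weaker inhibition and lower numbers for stronger inhibition. Compound 2 `COc1cc(OC)cc(C(=O)Nc2cccc(-c3oc4cc(-c5ccc(F)cc5)ccc4c(=O)c3O)c2)c1` gives 19600 nM, and compound 3 `Cc1cc(C)cc(C(=O)Nc2cccc(-c3oc4cc(-c5ccc(F)cc5)ccc4c(=O)c3O)c2)c1` gives 13500 nM. Compound 1 sits alongside both: the step of a 1.5-fold higher number from compound 1 to compound 2 (0.18 log units; within the scatter) and the step of a 1.0-fold higher number from compound 1 to compound 3 (0.02 log units; within the scatter) lie within the scatter, as does a 1.5-fold lower number from compound 2 to compound 3 (0.16 log units; within the scatter). Compound 4 `CCCc1ccc(C(=O)Nc2cccc(-c3oc4cc(-c5ccc(F)cc5)ccc4c(=O)c3O)c2)cc1` differs from compound 1 by ethyl in place of hydrogen on a saturated chain carbon bound to an aromatic carbon. For the measured compounds named here, none of the measured steps concerns a change of this kind; they swap substituents on the aryl ring bound to the carbonyl carbon, and none of them moved the number beyond the scatter. Compound 4 is therefore expected to give a number close to that of compound 1, with the step of a 1.0-fold higher number from compound 1 to compound 4 (0.00 log units; within the scatter) expected to stay within the scatter. His estimate for compound 4 is 13000 nM, with a range from 5000 nM to 35000 nM.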

Compound 4, half-maximal inhibitory concentration: 20400 nM
Compound 4: the middle estimate sits 1.6-fold (0.20 log units) below what was measured; measured number inside the range.
By their numbers in this assay, from the lowest: compounds 1, 3, 2 and 4 (each within the scatter of the next).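

In this assay, propyl in place of methyl, the only change shown on a saturated chain carbon bound to an aromatic carbon, gives a 1.6-fold higher number from compound 1 to compound 4 (0.20 log units; within the scatter) and so shows that this place takes the added ethyl without a step beyond the scatter. The 4-propylphenyl amide also stays within the scatter of the other two, with a 1.5-fold higher number from compound 3 to compound 4 (0.18 log units; within the scatter) and a 1.0-fold higher number from compound 2 to compound 4 (0.02 log units; within the scatter) as the steps. Nothing available here offers an explanation for these results. On these data alone, whether a longer chain, an amine or a carboxylic acid at this place would move the number beyond the scatter stays open.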